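The compounds below may be only part of what the source reports. "The series", "measured", "known", "first", "only" and "open" are said of these compounds alone.

Measured so far in an ADME assay on HEL cells (Homo sapiens) for cytotoxicity, with a stated time of 3 days; a lower number here means that less compound is tolerated, a higher number that more compound is tolerated:
compound 1 `CCCCCCCCCCc1cc2cn([C@H]3C[C@H](O)[C@@H](CO)O3)c(=O)nc2o1`: >= 130000 nM
compound 2 `CCCCCc1ccc(-c2cc3cn([C@H]4C[C@H](O)[C@@H](CO)O4)c(=O)nc3o2)nc1`: > 100000 nM

The value for compound 1 in this assay is a limit of the assay and not a number; it sits at the limit of >= 130000 nM in this assay, at which 1 of the 2 values shown sits. The value for compound 2 in this assay is likewise a limit, sitting at the limit of > 100000 nM in this assay, at which 1 of the 2 values shown sits. Both values shown are limits, so compound 1 stands where compound 2 stands, and no ordering between the two can be drawn from these numbers.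

Compound 3 `CCCc1ccc(CCc2cc3cn([C@H]4C[C@H](O)[C@@H](CO)O4)c(=O)nc3o2)cc1` is not yet measured. It differs from compound 1 by 4-propylphenyl in place of octyl on a saturated chain carbon, two bonds along the chain from an aromatic carbon. For the measured compounds named here, no step between measured compounds is available on which to size this change. With both measured values resting at limits, no step beyond the scatter is expected here, and compound 3 is expected to return a limit as well. The estimate for compound 3 in this assay is 130000 nM, within 60000 nM to 300000 nM, which means an expected step of a number no higher from compound 1 to compound 3 (the limit leaves the size open).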

Compound 3, minimum cytotoxic concentration: >= 130000 nM
Compound 3: no number, only a limit (the forecaster's own chance of this, stated with the estimate: 85%); the middle value lies on the limit itself.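

For the compounds shown here, compound 1 and compound 3 both rest on limits of this assay, so no step between them can be read. The compounds shown leave open the concentration at which any of them turns cytotoxic, and whether 4-propylphenyl in place of octyl shifts it.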